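Notes on a fused-core benzamide series in an oxidase assay

A few compounds are considered here, and "the series" means these few. Any claim that something is new, unique, unknown or untested is made for them only; others in the source may bear on it.

Measured compounds:
compound 1, `Cn1c(=O)c2[nH]c(-c3cccc(NC(=O)c4ccccc4)c3)nc2n(C)c1=O`, gives 18900 nM in an assay for inhibition of Amine oxidase [flavin-containing] B (Mus musculus), read by fluorescence, with a stated time of 30 min, in the presence of a further agent that is not named here; on this read-out lower numbers stand for stronger inhibition and higher numbers for weaker inhibition
compound 2, `COc1ccc(C(=O)Nc2cccc(-c3nc4c([nH]3)c(=O)n(C)c(=O)n4C)c2)cc1`, gives 16000 nM in this assay

Among the measured compounds shown here, only two compounds have numbers so far, and they are not separated: the single measured step, a 1.2-fold lower number from compound 1 to compound 2 (0.07 log units; within the scatter), stays within the scatter. Compound 2 therefore cannot be placed above or below compound 1; the two stand together on the one read-out available.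

The next compound is compound 3, `COc1ccc(C(=O)Nc2cccc(-c3nc4c(c(=O)n(C)c(=O)n4C)n3C)c2)cc1`. It differs from compound 2 by methyl in place of hydrogen on an aromatic nitrogen. For the measured compounds named here, no measured step touches this part of the shared core: the one step known concerns a methoxy on an aromatic carbon of the benzamide side, and it changed little. Going by the values given here, there is thus no measured precedent for the direction of the change from compound 2 to compound 3, and the expectation can only be cautious.

Compound 3 is expected to give 16000 nM, within a wide range from 4000 nM to 64000 nM. The expected step of no change at the digits printed from compound 2 to compound 3 (within the scatter) accordingly lies within the scatter, with the wide range reflecting the lack of a bearing step.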

Compound 3, half-maximal inhibitory concentration: 17800 nM
Compound 3: the middle estimate sits 1.1-fold (0.05 log units) below what was measured; measured number inside the range.
By their numbers in this assay, from the lowest: compounds 2, 3 and 1 (each within the scatter of the next).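

In this assay, among the compounds shown here, methyl in place of hydrogen on the aromatic nitrogen gives a 1.1-fold higher number from compound 2 to compound 3 (0.05 log units; within the scatter), the first measured step at this position of the shared core, and it lies within the scatter. Compound 2 and compound 3 are therefore not separated, so on this one pair the hydrogen on this nitrogen is not required for the read-out seen, and a methyl is accepted there without a measurable difference. No accompanying finding speaks to the origin of this result.

As far as these compounds go, whether a larger group on this nitrogen, such as an ethyl, a longer chain ending in an amine or one ending in a carboxylic acid, would also leave the number unseparated from that of compound 2 remains open, as does whether the same methyl gives a similar step on the benzamide of compound 1, which lacks the methoxy. From the compounds shown here alone, with all three compounds each within the scatter of the next, it is also open whether any change at this nitrogen or on the benzamide side can move the read-out beyond the scatter.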